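Chloro for trifluoromethyl on the urea aryl ring

The compounds below may be only part of what the source reports. "The series", "measured", "known", "first", "only" and "open" are said of these compounds alone.

Going by the values given here, compound 2, `COc1cc2cc(Oc3ccc(NC(=O)Nc4ccc(Cl)c(C(F)(F)F)c4)cc3)c(C)nc2cc1OC`, is the only member with a number rather than a limit in a functional assay on SF-268 cells (Homo sapiens) for inhibition, read by sulforhodamine B assay, with a stated time of 48 h; on this read-out higher numbers stand for lower toxicity in this test and lower numbers for higher toxicity in this test: compound 2 gives 22600 nM. Compound 1, `COc1cc2cc(Oc3ccc(NC(=O)Nc4cccc(C(F)(F)F)c4)cc3)c(C)nc2cc1OC`, stands at a limit of the assay, and in this assay compound 1 gives > 50000 nM. Among the compounds with values here, the one measured step, an at least 2.2-fold lower number from compound 1 to compound 2 (0.34 log units; beyond the scatter), reads against the backdrop of the limit of > 50000 nM in this assay, at which 1 of the 2 values shown sits, so its true size is open. Compound 3, `COc1cc2cc(Oc3ccc(NC(=O)Nc4ccc(Cl)c(Cl)c4)cc3)c(C)nc2cc1OC`, differs from compound 2 by chloro in place of trifluoromethyl on an aromatic carbon. Within the data shown here, no measured step alters a trifluoromethyl group, so the step from compound 1 to compound 2 does not bear directly on this change; it only shows that substitution at this part of the aryl ring moves the number by at least a modest amount. Among the measured compounds shown here, with no direct precedent, the expectation for compound 3 is a step within the scatter, a 1.1-fold higher number from compound 2 to compound 3 (0.04 log units; within the scatter), with a wide band. Compound 3 is thus estimated at 25000 nM in this assay, between 10000 nM and 60000 nM.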

Compound 3, concentration lethal to 50% of the cells: > 100000 nM
Compound 3 was reported as a limit; the forecaster's own chance of this, stated with the estimate: 35%; middle value at least 4.0-fold (0.60 log units) away from the limit.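

Trifluoromethyl at this position is now shown to count in its own right: in this assay, chloro in its place gives an at least 4.4-fold higher number from compound 2 to compound 3 (0.64 log units; beyond the scatter), a step opposite in direction to the earlier addition of chloro on the same ring. The value of compound 3, > 100000 nM, is a limit and not a number, so this step fixes a direction and a minimum size only: the limit of > 100000 nM in this assay, at which 1 of the 3 values shown sits. Among the three compounds, a number appears only with chloro and trifluoromethyl together on the aryl ring; compound 1 carries trifluoromethyl without chloro and compound 3 carries chloro without trifluoromethyl, and both sit at limits.

The step from compound 1 to compound 3 cannot be read, as both values are limits: the limit of > 50000 nM in this assay, at which 1 of the 3 values shown sits.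

From the compounds shown here alone, whether the number in compound 2 is specific to trifluoromethyl, or would also appear with a nitrile, a methoxy group or an amine at the same position, remains open, and so does the true size of each step that ends or starts at a limit.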